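Trimming the Ether Chain on the Shared Core

The source may report more compounds than this note shows. Statements on the series, on what has been measured and on what is new or still open speak of the compounds shown alone.

Compound 1, `C=CC(=O)Nc1cccc(Nc2ncnc(Nc3ccc(C(=O)Nc4ccc(C)cn4)cc3)n2)c1`: > 100000 nM in a functional assay on Ramos cells (Homo sapiens) for antiproliferative activity, read by CCK-8 assay, with a stated time of 24 h (on this read-out lower numbers stand for stronger inhibition and higher numbers for weaker inhibition), a limit of the assay
Compound 2, `C=CC(=O)Nc1cccc(Nc2ncnc(Nc3ccc(OCCOC)cc3)n2)c1`: 181000 nM

In this assay, going by the values given here, compound 2 gives 181000 nM, the only number among the two measured results. Compound 1 shows > 100000 nM, which is a limit of the assay and not a number. The step that the limit leaves unreadable from compound 1 to compound 2 therefore cannot be sized, because the limit of > 100000 nM in this assay, at which 1 of the 2 values shown sits, hides its extent.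

Compound 3, `C=CC(=O)Nc1cccc(Nc2ncnc(Nc3ccc(OC)cc3)n2)c1`, differs from compound 2 by hydrogen in place of methoxymethyl on a saturated chain carbon bound to an oxygen on an aromatic ring. Among the compounds with values here, no measured step reports this change, and the one measured step is unreadable, so nothing among the measured compounds points to a shift in either direction. Compound 3 is therefore expected to show a step of a 1.0-fold lower number from compound 2 to compound 3 (0.00 log units; within the scatter), which stays within the scatter. Compound 3 is estimated at 180000 nM, within the range 60000 nM to 500000 nM.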

Compound 3, half-maximal inhibitory concentration: 90000 nM
Estimate against measurement, compound 3: 2.0-fold (0.30 log units) above, within the range that was stated.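

Cutting 2-methoxyethoxy back to methoxy gives a 2.0-fold lower number from compound 2 to compound 3 (0.30 log units; within the scatter), so in this assay removing the methoxymethyl from this saturated chain carbon bound to an oxygen on an aromatic ring produces no change that can be told from the scatter. Compound 1 gives a limit of the assay and not a number: the limit of > 100000 nM in this assay, at which 1 of the 3 values shown sits. Compound 3 does offer a second number to set against that limit, but methoxy in place of (5-methylpyridin-2-yl)carbamoyl gives only a floor, an at least 1.1-fold lower number from compound 1 to compound 3 (0.04 log units; that floor lies within the scatter), and so does not establish a difference beyond the scatter.

The compounds shown leave open whether an amine or a carboxylic acid at the end of the chain on this oxygen would move the number beyond the scatter. Going by these compounds, a longer chain at the same place remains equally open.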